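This account rests on a few compounds, and the source may have more. Where it says the series, first, only, none or still open, it means among the compounds named here.

Working notes on the series. Compound 1 `C[C@H]1O[C@@H](n2cnc3c(N)nc(OC4CCCC4)nc32)[C@H](O)[C@@H]1OCc1ccc(Cl)c(Cl)c1` sits at the edge of a physicochemical assay for solubility, measured as thermodynamic solubility (a lower number here means a less soluble compound, a higher number a more soluble compound), recording < 1000 nM, which is a limit of the measurement rather than a number. Going by the values given here, compound 2 `C[C@H]1O[C@@H](n2cnc3c(N)nc(OCC4CC45CC5)nc32)[C@H](O)[C@H]1Cl` gives 21000 nM in this assay, the only actual number in the set so far. The remaining entry is the limit of compound 1 (the limit of < 1000 nM in this assay, at which 1 of the 2 values shown sits). Compound 3 `C[C@H]1O[C@@H](n2cnc3c(N)nc(OC4CCCC4)nc32)[C@H](O)[C@H]1Cl`, not yet measured, differs from compound 2 by a group of 5 heavy atoms (5 carbon; one five-membered non-aromatic ring of carbon only) in place of a group of 6 heavy atoms (6 carbon; 2 three-membered non-aromatic rings of carbon only), on an oxygen on an aromatic ring. Among the compounds with values here, no measured pair shows how such a change moves solubility; compound 1 carries the cyclopentyl group but also differs from compound 3 in another part of the molecule, so its limit gives no direct guide. The step is expected to be modest, with a slight fall in solubility somewhat more likely than a rise: a 1.5-fold lower number from compound 2 to compound 3 (0.18 log units; within the scatter). Compound 3 is therefore expected to give about 14000 nM in this assay, within 4000 nM to 40000 nM.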

Compound 3, solubility: 304000 nM
For compound 3 the middle estimate is 22-fold (1.34 log units) below the measured one, outside the stated range (above it).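

At this oxygen on an aromatic ring, putting cyclopentyl in place of the group with 2 three-membered rings gives, in this assay, a 14-fold higher number from compound 2 to compound 3 (1.16 log units; beyond the scatter), with the rest of the molecule unchanged. This first measured pair in the series shows that the carbon group at this place alone can move the read-out well beyond the scatter, although neither group carries a hydrogen-bond donor or acceptor. Nothing measured in the series accounts for the size of this step.

From the compounds shown here alone, whether a longer chain, an amine or a carboxylic acid on this oxygen would follow compound 2 or compound 3 remains open. A single pair also leaves open whether the step would carry over when the chlorine of both compounds is replaced by another group.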